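Swapping a hydroxyethyl side chain for an aminobutyl chain

The source may hold more compounds than are shown below. What is called first, only, known or untested is meant among the compounds shown, and "the series" means these compounds.

Compound 1, `N=C(N)NCCC[C@H](NC(=O)CN(c1nc(Cl)nc2[nH]cnc12)C1CC1)C(=O)O`, gives 7.19% in a functional assay on the whole organism (Tail, strain ICR) with Mus musculus as the target, in the tail flick test, with a stated time of 150 min, at a dose of 25 umol/kg by the oral route; a lower number here means a weaker effect, a higher number a stronger effect of the compound at the dose given.
Compound 2, `C[C@@H](O)[C@H](NC(=O)CN(c1nc(Cl)nc2[nH]cnc12)C1CC1)C(=O)O`, gives 24% in this assay.

Going by the values given here, compound 2 stands highest of the two numbers measured so far; its only neighbour is compound 1, and the single measured step is a number 16.8 percentage points higher from compound 1 to compound 2 (beyond the scatter). Compound 3, `NCCCC[C@H](NC(=O)CN(c1nc(Cl)nc2[nH]cnc12)C1CC1)C(=O)O`, differs from compound 2 in one place: 4-aminobutyl in place of 1-hydroxyethyl on a saturated chain carbon bound to an amide-type nitrogen and a carbonyl carbon. The step from compound 1 to compound 2 is the only one that bears on this change, because there a number 16.8 percentage points higher from compound 1 to compound 2 (beyond the scatter) came with the loss of a nitrogen-bearing chain at the same place. Among the compounds with values here, compound 3 carries the 4-aminobutyl group, a chain closer in kind to the one in compound 1 than to the 1-hydroxyethyl group of compound 2, so its read-out is expected to move back toward that of compound 1. The expected step is therefore a number 12 percentage points lower from compound 2 to compound 3 (beyond the scatter), downward and only just beyond the scatter. Compound 3 is estimated at 12% in this assay, with a range from 0% to 28%.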

Compound 3, a percentage reported as activity, at one dose (the size of the read-out at that dose, not a potency): 11.6%
For compound 3 the middle estimate is 0.4 percentage points above the measured one; the range from low to high includes it.
By their numbers in this assay, from the lowest: compounds 1 and 3 (each within the scatter of the next); then compound 2.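

In this assay, placing 4-aminobutyl in place of 1-hydroxyethyl on a saturated chain carbon bound to an amide-type nitrogen and a carbonyl carbon gives a number 12.4 percentage points lower from compound 2 to compound 3 (beyond the scatter), so the lower read-out at this position now goes with two different nitrogen-bearing chains and not with the chain of compound 1 alone. The change between those two chains gives a number 4.4 percentage points higher from compound 1 to compound 3 (within the scatter), so this assay does not separate them, and the difference in their nitrogen-bearing groups shows no effect that can be read here. Among the three compounds, only the 1-hydroxyethyl group of compound 2 stands apart, and nothing measured here accounts for that.

The compounds shown leave open whether the higher read-out follows the hydroxyl group or the shorter chain, a question that a 4-hydroxybutyl chain or a plain ethyl group would help to settle. They also leave open how a chain ending in a carboxylic acid would read, and with one dose and one time point, these steps describe the size of the effect under those conditions and not potency.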